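Cyclohexyl to Cyclohexylethyl Amides in a Cytotoxicity Screen

A few compounds are considered here, and "the series" means these few. Any claim that something is new, unique, unknown or untested is made for them only; others in the source may bear on it.

Compound 2 `O=C(Nc1ncc(Cc2cccc3sccc23)s1)C1CCCCC1` and compound 1 `O=C(CCC1CCCCC1)Nc1ncc(Cc2cccc3sccc23)s1` share a core and differ at one point, where (2-cyclohexylethyl in place of cyclohexyl on a carbonyl carbon). In an ADME assay on P388D1 cells (Mus musculus) for cytotoxicity, read by fluorescence and resazurin assay, with a stated time of 72 h (on this read-out lower numbers stand for stronger inhibition and higher numbers for weaker inhibition), compound 2 gives a value that is a limit of the assay, > 40000 nM. Compound 1 also gives only a limit in this assay, > 40000 nM. The step between them is a step that the two limits leave unreadable from compound 2 to compound 1; what the pair shows is the limit of > 40000 nM in this assay, at which 2 of the 3 values shown sit.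

Compound 3 `O=C(Nc1ncc(Cc2csc3ccccc23)s1)C1CCCCC1` is made of the same atoms as compound 2 joined differently, and the difference between the two cores is not broken down here. For compound 3 the outcome in this assay stands as "not determined" (no result reported).

Compound 4 `O=C(CCC1CCCCC1)Nc1ncc(Cc2csc3ccccc23)s1` carries the same change relative to compound 3 that compound 1 carries relative to compound 2: 2-cyclohexylethyl in place of cyclohexyl on a carbonyl carbon, at an identical place. Compound 4 is expected to sit near 60000 nM, an estimate resting on the unreadable step that the two limits leave unreadable from compound 2 to compound 1. For compound 4 the expected spread runs from 30000 nM to 200000 nM, with a high chance that the assay again reports only a limit rather than a number.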

Compound 4, half-maximal inhibitory concentration: 16900 nM
Beside the measured number, compound 4's estimate is 3.6-fold (0.55 log units) above it; measured number below the stated range.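

No new step can be read from compound 3 to compound 4: in this assay compound 3 stands as "not determined" (no result reported), while compound 4 gives 16900 nM. The compounds shown leave open what 2-cyclohexylethyl in place of cyclohexyl on a carbonyl carbon does on either core, and how the two cores compare, with several values resting on one limit: the limit of > 40000 nM in this assay, at which 2 of the 4 values shown sit.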